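A few compounds are considered here, and "the series" means these few. Any claim that something is new, unique, unknown or untested is made for them only; others in the source may bear on it.

Working notes on the series. In a functional assay on cells (Neutrophil, Homo sapiens) for inhibition, with a stated time of 10 min (on this read-out lower numbers stand for stronger inhibition and higher numbers for weaker inhibition), compound 2 `CCOC(=O)c1cnn(CC(C)O)c1NC(=O)Nc1ccc(F)cc1` gives 0.2 nM, the highest of the three numbers shown. Compound 1 `CCOC(=O)c1cnn(CC(O)CC)c1NC(=O)NC(C)C` gives 0.0042 nM and compound 3 `CCOC(=O)c1cnn(C)c1NC(=O)NC(C)C` gives 0.0018 nM; both carry isopropyl on the amide-type nitrogen where compound 2 carries 4-fluorophenyl, and both sit far below compound 2. For the measured compounds named here, the single step within one place, a 2.3-fold lower number from compound 1 to compound 3 (0.37 log units; beyond the scatter), concerns the chain on the aromatic nitrogen and does not bear on the present change. Compound 4 `CCOC(=O)c1cnn(CC(C)O)c1NC(=O)NCc1ccccc1` differs from compound 2 by benzyl in place of 4-fluorophenyl on an amide-type nitrogen. Going by the values given here, no measured step covers this exchange; the lower numbers of compounds 1 and 3 with a non-aromatic group on that nitrogen suggest a move downward, so a modest drop a 4.0-fold lower number from compound 2 to compound 4 (0.60 log units; beyond the scatter) is expected. Compound 4 is estimated at 0.05 nM, between 0.005 nM and 0.5 nM.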

Compound 4, half-maximal inhibitory concentration: 0.00054 nM
Estimate against measurement, compound 4: 93-fold (1.97 log units) above, outside the stated range (below it).
By their numbers in this assay, from the lowest: compound 4; then compound 3; then compound 1; then compound 2.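

In this assay, the amide-type nitrogen proves highly sensitive to this exchange: benzyl in place of 4-fluorophenyl gives a 370-fold lower number from compound 2 to compound 4 (2.57 log units; beyond the scatter), a large step between groups of equal heavy-atom count. An aromatic ring in the group on this nitrogen is therefore compatible with a very low number. No measurement at hand accounts for the size of this step. The exchange removes fluorine and adds a carbon at once, and the compounds shown do not separate these two changes. On these data alone, how phenyl or 4-fluorobenzyl on this nitrogen would read remains open.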